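A few compounds are considered here, and "the series" means these few. Any claim that something is new, unique, unknown or untested is made for them only; others in the source may bear on it.

Measured compounds:
- compound 1 `COc1ccccc1C(=O)NCCNc1cccc(NS(=O)(=O)c2cc(-c3cccc(C(=O)N(C)C)c3)ccc2OC)c1`: 5230 nM
- compound 2 `COc1ccc(-c2cccc(C(=O)N(C)C)c2)cc1S(=O)(=O)Nc1cccc(NCCNC(=O)c2ccccc2)c1`: "not determined" (no result reported)

Working notes on the series.

Going by the values given here, compound 1 `COc1ccccc1C(=O)NCCNc1cccc(NS(=O)(=O)c2cc(-c3cccc(C(=O)N(C)C)c3)ccc2OC)c1` is the only member with a number in a functional assay on CHO-K1 cells for agonist activity at Orexin/Hypocretin receptor type 1 (Homo sapiens), read by calcium flux; on this read-out higher numbers stand for an effect only at larger amounts of compound and lower numbers for an effect already at smaller amounts: compound 1 gives 5230 nM, a weak response. Compound 2 `COc1ccc(-c2cccc(C(=O)N(C)C)c2)cc1S(=O)(=O)Nc1cccc(NCCNC(=O)c2ccccc2)c1` carries an unsubstituted benzamide on the same shared core, but in this assay compound 2 has no result, so it stands nowhere on the numbers shown; the only anchor for the series is compound 1.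

Compound 3 `COc1cccc(C(=O)NCCNc2cccc(NS(=O)(=O)c3cc(-c4cccc(C(=O)N(C)C)c4)ccc3OC)c2)c1` follows from compound 2 by the change methoxy in place of hydrogen on an aromatic carbon: a methoxy in place of hydrogen on an aromatic carbon, meta to a large group, turning the benzoyl into a (3-methoxyphenyl)carbonyl. With compound 2 unmeasured, no step can be computed, and no direction for this change is backed by a listed pair. Compound 1 shows that a methoxy-bearing benzamide on this core is tolerated only at a high concentration, and nothing here points to compound 3 departing far from that level. Compound 3 is therefore expected to give about 5000 nM in this assay, within a range of 1500 nM to 15000 nM, with a real chance that only a limit is returned.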

Compound 3, half-maximal effective concentration: 9250 nM
Compound 3: the middle estimate sits 1.9-fold (0.27 log units) below what was measured, and the stated range covers the measured number.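

In this assay the methoxy on the benzamide phenyl can take either of the two places shown without a shift beyond the scatter: a 1.8-fold higher number from compound 1 to compound 3 (0.25 log units; within the scatter), so 3-methoxyphenyl and 2-methoxyphenyl cannot be told apart on this read-out. Going by these compounds alone, this is the only pair with a number on both sides that differs in one place, and it puts compound 1 and compound 3 at the same weak level of response, which gives the series a second anchor and shows that this level is not tied to a single placement of the methoxy. Nothing available bears on why the two placements read alike.

On these data alone, the step from compound 2 to compound 3 cannot be read, as compound 2 has no number, so what the methoxy contributes relative to hydrogen on this phenyl remains unknown. Also open, as far as these compounds go, is whether a different group at this position, such as an amine, a carboxylic acid or a longer chain in place of the methoxy, would move the response in this assay clear of the scatter in either direction.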